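Methoxy for bromo on the aromatic ring

The source may hold more compounds than are shown below. What is called first, only, known or untested is meant among the compounds shown, and "the series" means these compounds.

Working notes on the series cover two measured compounds in a functional assay on 786-0 cells (Homo sapiens) for inhibition, read by sulforhodamine B assay, with a stated time of 48 h; on this read-out higher numbers stand for weaker inhibition of growth and lower numbers for stronger inhibition of growth. Compound 1 `COc1ccc(-c2c(CNC(C)(C)C)c(C(=O)O)nn2-c2ccccc2)cc1` reports only a limit, > 659000 nM. Within the data shown here, compound 2 `CC(C)(C)NCc1c(C(=O)O)nn(-c2ccc(Cl)cc2)c1-c1ccc(Br)cc1` gives 542000 nM, which is the only actual number so far, so it has no numerical neighbour to be ranked against.

The next compound is compound 3 `COc1ccc(-c2c(CNC(C)(C)C)c(C(=O)O)nn2-c2ccc(Cl)cc2)cc1`. The change from compound 2 is methoxy in place of bromo on an aromatic carbon, para to a large group. Among the measured compounds shown here, no measured pair in this assay isolates this change, so no step beyond the scatter is expected in either direction. The 4-methoxyphenyl group also occurs in compound 1, which sits at the limit of > 659000 nM. That result leaves open the possibility that compound 3 also reports only a limit. The expected 1.1-fold higher number from compound 2 to compound 3 (0.04 log units; within the scatter) is small and has no firm direction. Compound 3 is expected at 600000 nM, with an estimated range of 300000 nM to 1200000 nM.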

Compound 3, concentration for 50% growth inhibition: > 605000 nM
Compound 3 was reported as a limit (the forecaster's own chance of this, stated with the estimate: 50%); middle value at least 1.0-fold (0.00 log units) away from the limit.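

Taking 4-bromophenyl to 4-methoxyphenyl gives an at least 1.1-fold higher number from compound 2 to compound 3 (0.04 log units; that floor lies within the scatter) in this assay, and this is the only pair shown that isolates the change on this aromatic carbon, para to a large group. Compound 3 reports a limit, > 605000 nM, not a number, so that step is only a floor and gives no evidence of a real shift in either direction. The 4-methoxyphenyl group now gives a limit in both compounds that carry it, which leaves the step for chloro in place of hydrogen on an aromatic carbon unreadable and leaves compound 2 as the only compound with an actual number: the limit of > 605000 nM in this assay, at which 1 of the 3 values shown sits.

On these data alone, how far compound 3 actually lies from compound 2 remains open, since the data give no upper bound on its value. Also open, as far as these compounds go, is whether an amine or a nitrile in place of the bromo would give a lower number in this assay than the values seen here.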